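The source may report more compounds than this note shows. Statements on the series, on what has been measured and on what is new or still open speak of the compounds shown alone.

Measured so far in a functional assay on HCT-116 cells (Homo sapiens) for antiproliferative activity, read by MTT assay, with a stated time of 24 h; a higher number here means a weaker inhibitor, a lower number a stronger inhibitor:
Compound 1 `COc1ccc(C(=O)/C=C/c2cccc(Cl)c2)c2c1C=CC(C)(C)O2`: > 10000 nM (a limit)
Compound 2 `COc1ccc(C(=O)/C=C/c2cccc(O)c2)c2c1C=CC(C)(C)O2`: > 10000 nM (a limit)

Compound 2 stands at > 10000 nM, which is a limit of the assay and not a number. Its position is shared with compound 1: the limit of > 10000 nM in this assay, at which 2 of the 2 values shown sit.

Compound 3 `COc1ccc(C(=O)/C=C/c2cc(Cl)ccc2O)c2c1C=CC(C)(C)O2` changes one part of compound 2: 5-chloro-2-hydroxyphenyl in place of 3-hydroxyphenyl on a double-bonded chain carbon bound to a double-bonded chain carbon. Here 5-chloro-2-hydroxyphenyl takes the place of 3-hydroxyphenyl on a double-bonded chain carbon bound to a double-bonded chain carbon.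

Within the data shown here, only one measured step bears on this change, a step that the two limits leave unreadable from compound 1 to compound 2, which swaps chloro for hydroxy on an aromatic carbon. It offers no size to carry over, so no clear shift in either direction is expected in this assay, and a further limit is the likeliest outcome. The expected step is a step that the limit leaves unreadable from compound 2 to compound 3. For compound 3 the estimated value is 15000 nM, with an expected range from 5000 nM to 50000 nM.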

Compound 3, half-maximal inhibitory concentration: 5240 nM
Estimate against measurement, compound 3: 2.9-fold (0.46 log units) above, and the stated range covers the measured number.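

In this assay, compound 3 is the only compound shown that gives a number and not a limit, so a group on this double-bonded chain carbon can bring a readable value: the limit of > 10000 nM in this assay, at which 2 of the 3 values shown sit.

Putting 5-chloro-2-hydroxyphenyl in place of 3-hydroxyphenyl gives an at least 1.9-fold lower number from compound 2 to compound 3 (0.28 log units; that floor lies within the scatter), and the added hydroxy gives an at least 1.9-fold lower number from compound 1 to compound 3 (0.28 log units; that floor lies within the scatter). Both figures are only floors, so neither step can yet be said to clear the usual scatter, and the step from compound 1 to compound 2 cannot be read.

The compounds shown leave open what 2-hydroxyphenyl without the chloro would give, so the share of each group in the readable value stays unknown. Also open, on these data alone, is whether an amine or a carboxylic acid in place of that hydroxy would keep a readable value.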